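Chloro to hydroxy on the benzylidene ring: compound 3

The source may hold more compounds than are shown below. What is called first, only, known or untested is meant among the compounds shown, and "the series" means these compounds.

The series shares the core of compound 1 `O=C1/C(=C/c2cccc(Cl)c2)Cc2cc(O)ccc21`, which in an assay on isolated protein for inhibition of Amine oxidase [flavin-containing] B (Homo sapiens), read by fluorescence and spectrophotometry, with a stated time of 20 min (a lower number here means a stronger inhibitor, a higher number a weaker inhibitor), gives 30 nM. Compound 2 `O=C1/C(=C/c2ccc(Cl)c(Cl)c2)Cc2cc(O)ccc21` carries an added chloro and in this assay gives 14 nM. Among the measured compounds shown here, of the two numbers measured, compound 1 is the higher, with compound 2 as its only neighbour; the step of a 2.1-fold lower number from compound 1 to compound 2 (0.33 log units; beyond the scatter) is the sole measured step in the set.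

Compound 3 `O=C1/C(=C/c2cccc(O)c2)Cc2cc(O)ccc21` differs from compound 1 by hydroxy in place of chloro on an aromatic carbon. For the measured compounds named here, no measured step exchanges the chloro for another group; the one step known concerns adding a chloro elsewhere and bears on this change only indirectly, showing that the ring tolerates a further chloro with a modest gain in this assay. For the exchange to hydroxy no comparable reading exists, so the expectation rests on compound 1 alone.

For compound 3 the number in this assay is expected to be around 100 nM, within a range of 25 nM to 400 nM. The step expected from compound 1 to compound 3 is a 3.3-fold higher number from compound 1 to compound 3 (0.52 log units; beyond the scatter), a modest rise, though a result within the scatter would not be surprising.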

Compound 3, half-maximal inhibitory concentration: 966 nM
Compound 3: middle estimate off by 9.7-fold (0.98 log units), on the low side, and the stated range ends below it.
By their numbers in this assay, from the lowest: compound 2; then compound 1; then compound 3.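

In this assay, replacing chloro with hydroxy on this aromatic carbon, meta to a large group, gives a 32-fold higher number from compound 1 to compound 3 (1.51 log units; beyond the scatter), so the group at this position has a large effect on the number. The earlier pair showed only that a further chloro on the ring goes with a modest change, a 2.1-fold lower number from compound 1 to compound 2 (0.33 log units; beyond the scatter), and gave no sign of how much depends on the chloro that compound 1 carries here. Nothing in hand accounts for the size of this step.

As far as these compounds go, with only chloro and hydroxy compared at this position, it remains open whether the rise reflects the departure of chloro or the arrival of hydroxy; unsubstituted hydrogen, methoxy or an amine here would help separate the two. Also open, from the compounds shown here alone, is whether the further chloro of compound 2 would bring any gain alongside the hydroxy of compound 3.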